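The compounds below may be only part of what the source reports. "The series", "measured", "known", "first", "only" and "open" are said of these compounds alone.

Compound 1 `CCN(Cc1ccccc1)C(=O)C1CCN(S(=O)(=O)c2cccc(OC)c2)CC1`, compound 2 `CCN(Cc1ccccc1)C(=O)C1CCN(S(=O)(=O)c2c[nH]cn2)CC1` and compound 3 `CCN(Cc1ccccc1)C(=O)C1CCN(S(=O)(=O)c2ccc(C)s2)CC1` share one core and differ only in the ring on the sulfonyl sulfur. In a functional assay on CHO cells for positive allosteric modulation of muscarinic acetylcholine receptor M5 (Homo sapiens), read by calcium flux (on this read-out lower numbers stand for smaller maximal responses and higher numbers for larger maximal responses), compound 1 gives 77% and compound 3 gives 64%, while compound 2 gives "not determined" (no result reported), so compound 2 has no number to stand on. Compound 4 `CCN(Cc1ccccc1)C(=O)C1CCN(S(=O)(=O)c2ccc3[nH]ncc3c2)CC1` is reached from compound 2 by a single change: 1H-indazol-5-yl in place of 1H-imidazol-4-yl on a sulfonyl sulfur. Among the compounds with values here, the only measured step, a number 13 percentage points lower from compound 1 to compound 3 (beyond the scatter), shows that swapping the ring on the sulfonyl sulfur moves the largest response only modestly, and neither measured ring matches the one entering compound 4. For compound 4 the largest response in this assay is therefore expected near 68%, within a range of 48% to 88%.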

Compound 4, largest response reached (reported as percent of maximum), in percent of the reference or control that the assay uses: 86%
Beside the measured number, compound 4's estimate is 18 percentage points below it; the range from low to high includes it.
By their numbers in this assay, from the lowest: compound 3; then compounds 1 and 4 (each within the scatter of the next).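

In this assay, 1H-indazol-5-yl on the sulfonyl sulfur gives a number 22 percentage points higher from compound 3 to compound 4 (beyond the scatter), but a number 9 percentage points higher from compound 1 to compound 4 (within the scatter). The position therefore accepts a group with two aromatic rings and a hydrogen-bond donor, and the largest response stays level with that of compound 1. No measurement shown here explains these differences.

With no number for compound 2, the step from it to compound 4 cannot be read. Still open, as far as these compounds go, is how the largest response would change with a phenyl ring carrying an amine or a carboxylic acid on this sulfur.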